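Thiophene to Methylpyrazole at the Amide Carbonyl

This account rests on a few compounds, and the source may have more. Where it says the series, first, only, none or still open, it means among the compounds named here.

Compound 1: `CCCCCCCCCCCC[C@@H](O)[C@H]1CC[C@H]([C@H](O)CCCCCCCCCCNC(=O)c2cccs2)O1` — 17000 nM
Compound 2: `CCCCCCCCCCCC[C@@H](O)[C@H]1CC[C@H]([C@H](O)CCCCCCCCCCNC(=O)c2ccsc2)O1` — 100000 nM

Two amides of the same core have been measured in a functional assay on SF-539 cells (Homo sapiens) for inhibition, read by colorimetric assay and sulforhodamine B assay, with a stated time of 48 h; a lower number here means a stronger inhibitor of growth, a higher number a weaker inhibitor of growth. Compound 1, which carries the thiophen-2-yl group on the carbonyl carbon, gives 17000 nM; compound 2, which carries thiophen-3-yl instead, gives 100000 nM. Among the compounds with values here, compound 1 therefore stands as the lower of the two numbers, and the only measured step, a 5.9-fold higher number from compound 1 to compound 2 (0.77 log units; beyond the scatter), shows how much a change of the aromatic ring on the carbonyl carbon can move this read-out.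

Compound 3 is `CCCCCCCCCCCC[C@@H](O)[C@H]1CC[C@H]([C@H](O)CCCCCCCCCCNC(=O)c2ccnn2C)O1`. It differs from compound 1 in one place: 1-methyl-1H-pyrazol-5-yl in place of thiophen-2-yl on a carbonyl carbon. Within the data shown here, no measured step covers this exact exchange; the step of a 5.9-fold higher number from compound 1 to compound 2 (0.77 log units; beyond the scatter) bears on it only as another replacement of the ring on the carbonyl carbon, and that step made the number larger. Without a closer precedent, compound 3 is expected to come out as a weaker inhibitor than compound 1 or at best comparable, with a step of about a 2.1-fold higher number from compound 1 to compound 3 (0.31 log units; beyond the scatter) expected. The estimate for compound 3 in this assay is 35000 nM, with a range from 10000 nM to 100000 nM.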

Compound 3, concentration for 50% growth inhibition: 3720 nM
The estimate for compound 3 lay 9.4-fold (0.97 log units) above the measured number, outside the stated range (below it).
By their numbers in this assay, from the lowest: compound 3; then compound 1; then compound 2.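

The earlier step had shown only a rise in the number on changing the ring on this carbonyl carbon, but in this assay the exchange for 1-methyl-1H-pyrazol-5-yl moves it the other way, with a 4.6-fold lower number from compound 1 to compound 3 (0.66 log units; beyond the scatter) and, against the thiophen-3-yl amide, a 27-fold lower number from compound 2 to compound 3 (1.43 log units; beyond the scatter); both steps lie beyond the scatter, so compound 3 is the strongest inhibitor of growth of the three, and the ring on the carbonyl carbon can shift this read-out in either direction. The exchange from thiophen-2-yl replaces sulfur with nitrogen, adds a methyl group and changes the counts of heavy atoms, ring hetero atoms and hydrogen-bond acceptors all at once, so these three compounds cannot assign the lower number to any one of those differences. No supporting measurement is available that would explain the shift.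

The compounds shown leave open how much of the lower number belongs to the methyl group of compound 3 and how much to the ring nitrogen atoms, a question that a pyrazole ring without the methyl group would address. They also leave open how a phenyl or pyridine ring on the same carbonyl carbon would compare.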